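Cytotoxicity of coumarins: from heptyloxy to acetyl

The compounds below may be only part of what the source reports. "The series", "measured", "known", "first", "only" and "open" are said of these compounds alone.

Compound 1 `CC(C)CCc1cccc2ccc(=O)oc12` gives 60000 nM in a functional assay on V79 cells (Cricetulus griseus) for cytotoxicity; on this read-out higher numbers stand for weaker inhibition and lower numbers for stronger inhibition
Compound 2 `CCOc1ccc2ccc(=O)oc2c1CCC(C)C` gives 5800 nM in this assay
Compound 3 `CCCCCCCOc1ccc2ccc(=O)oc2c1CCC(C)C` gives 17000 nM in this assay

Compound 3 holds the second highest of the three numbers: its nearest neighbour is compound 2, with a 2.9-fold higher number from compound 2 to compound 3 (0.47 log units; beyond the scatter), and the furthest is compound 1, with a 3.5-fold lower number from compound 1 to compound 3 (0.55 log units; beyond the scatter). The unmeasured compound 4 `CC(=O)c1ccc2ccc(=O)oc2c1CCC(C)C` differs from compound 3 in one place: acetyl in place of heptyloxy on an aromatic carbon.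

Going by the values given here, no measured step exchanges one substituent for another of a different kind at this carbon; the steps that bear on it are those that install a group there, a 10-fold lower number from compound 1 to compound 2 (1.01 log units; beyond the scatter) and a 3.5-fold lower number from compound 1 to compound 3 (0.55 log units; beyond the scatter), both lowering the number, the shorter group more so, and a 2.9-fold higher number from compound 2 to compound 3 (0.47 log units; beyond the scatter), which shows a modest rise on lengthening the chain. Acetyl is small, like ethoxy, but not an alkoxy, so the direction is uncertain. Compound 4 is therefore expected to sit close to compound 3, with a 1.1-fold lower number from compound 3 to compound 4 (0.05 log units; within the scatter), at an estimated 15000 nM, ranging from 4000 nM to 60000 nM.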

Compound 4, half-maximal inhibitory concentration: 60000 nM
The estimate for compound 4 lay 4.0-fold (0.60 log units) below the measured number; low and high end bracket the measured number.
By their numbers in this assay, from the lowest: compound 2; then compound 3; then compounds 1 and 4 (each within the scatter of the next).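

Installing a group at this aromatic carbon, ortho to the isopentyl group, does not always shift the number in this assay: acetyl in place of hydrogen gives no change at the digits printed from compound 1 to compound 4 (within the scatter), whereas ethoxy and heptyloxy both gave lower numbers. Exchanging an alkoxy group for acetyl gives a 3.5-fold higher number from compound 3 to compound 4 (0.55 log units; beyond the scatter) and a 10-fold higher number from compound 2 to compound 4 (1.01 log units; beyond the scatter), so among these compounds the smaller acetyl group does not match either alkoxy group, and small size alone does not go with the lowest number. Nothing available here explains why acetyl differs from the two alkoxy groups.

Going by these compounds, whether a hydroxyl, an amine or a carboxylic acid at this carbon would follow the alkoxy groups or acetyl remains open. So does the course of the number across chains of intermediate length, such as propoxy or butoxy.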